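The compounds below may be only part of what the source reports. "The series", "measured", "known", "first", "only" and "open" are said of these compounds alone.

Measured compounds in a functional assay on COS-7 cells (Chlorocebus aethiops) for inhibition, read by MTT assay; a higher number here means a weaker inhibitor, a lower number a stronger inhibitor:
- Compound 1, `Cc1ccc2c(c1)/C(=N/NC(=S)N/N=C/c1ccccn1)C(=O)N2`, gives 2120 nM.
- Compound 2, `O=C1Nc2ccc(Br)cc2/C1=N/NC(=S)N/N=C/c1ccc2ccccc2c1`, reaches only the assay limit of > 50000 nM.
- Compound 3, `COc1ccc(/C=N/NC(=S)N/N=C2\C(=O)Nc3ccc(C)cc32)c(OC)c1`, likewise reaches only the assay limit of > 50000 nM.

For the measured compounds named here, compound 1 therefore stands alone as the one compound with a number in this assay; the other two sit at the limit of > 50000 nM in this assay, at which 2 of the 3 values shown sit, so no ordering among the three can be read beyond that compound 1 is the only one with a measurable value.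

Compound 4, `Cc1ccc(O)c(/C=N/NC(=S)N/N=C2\C(=O)Nc3ccc(C)cc32)c1`, has not yet been measured. Compared with compound 1 its structure differs in one place, as 2-hydroxy-5-methylphenyl in place of pyridin-2-yl on a carbon with a double bond to nitrogen.

Going by the values given here, there is no measured pair that differs in exactly one place, so the size of this step can only be guessed from the three values shown. Compound 3, which also carries a six-membered aromatic ring of carbon only on the carbon with a double bond to nitrogen, reaches only the limit > 50000 nM, and that weighs toward a weaker inhibitor. For compound 4 the expected step is a 5.7-fold higher number from compound 1 to compound 4 (0.75 log units; beyond the scatter), a move toward weaker inhibition. Compound 4 is therefore estimated at 12000 nM, within a range from 3000 nM to 50000 nM, with a real chance that the assay again reports only a limit.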

Compound 4, half-maximal inhibitory concentration: > 50000 nM
Compound 4 gave a limit, no number (the forecaster's own chance of this, stated with the estimate: 35%); middle value at least 4.1-fold (0.61 log units) away from the limit.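

In this assay, for the compounds shown here, replacing pyridin-2-yl with 2-hydroxy-5-methylphenyl on a carbon with a double bond to nitrogen gives an at least 23-fold higher number from compound 1 to compound 4 (1.37 log units; beyond the scatter), the first step in this set that can be read at a single place. With the rest of compound 1 unchanged, this one substitution is enough to turn a compound with a measurable value into one that reads only as a limit, so this position clearly matters for the read-out. Among the compounds shown, pyridin-2-yl is the only group here paired with a number, while the limit is the common result: the limit of > 50000 nM in this assay, at which 3 of the 4 values shown sit.

The change swaps the ring nitrogen of pyridin-2-yl for a carbon-only ring and also brings in a hydroxyl and a methyl group, and the compounds shown cannot say which of these differences accounts for the step. Plain phenyl, pyridin-3-yl or a pyridin-2-yl ring carrying a small amine would help to separate those differences and show whether the ring nitrogen and its place in the ring are what compound 1 depends on.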